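The compounds below may be only part of what the source reports. "The series", "measured", "known", "first", "only" and "open" are said of these compounds alone.

Measured compounds in a functional assay on the whole organism for inhibition, with Rattus norvegicus as the target, at a dose of 50 mg/kg by the oral route; on this read-out lower numbers stand for less inhibition and higher numbers for more inhibition at the one dose given (going by the name of the read-out):
compound 1 `CCOC(=O)c1c(CSc2nncn2C)nc2cc(OC)c(OC)cc2c1-c1ccc(OC)c(OC)c1`, 66%
compound 2 `CCOC(=O)c1c(CSc2nccn2C)nc2cc(OC)c(OC)cc2c1-c1ccc(C)cc1`, 67%
compound 3 `COc1ccc(-c2nc(CSc3nccn3C)nc3cc(OC)c(OC)cc23)cc1OC`, < 50%

Compound 1 and compound 2 sit within the scatter of each other in this assay, so no order between them is claimed. For compound 3 this assay reports only a limit, < 50%. For the measured compounds named here, that limit is the point named in the limit of < 50% in this assay, at which 1 of the 3 values shown sits, and compound 3 is the one value of the three that rests there rather than at a number; how far it lies from compounds 1 and 2 cannot be read from the data.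

Compound 4 `COc1ccc(-c2nc(CCc3nccn3C)nc3cc(OC)c(OC)cc23)cc1OC` is not yet measured. It differs from compound 3 in one place: (1-methyl-1H-imidazol-2-yl)methyl in place of (1-methyl-1H-imidazol-2-yl)sulfanyl on a saturated chain carbon bound to an aromatic carbon. Going by the values given here, no pair of measured compounds shows this change, so its effect is unknown. Starting from a limit, the expectation for compound 4 is a step that the limit leaves unreadable from compound 3 to compound 4 that stays within the usual scatter, with a fair chance the assay again returns only a limit. The estimated value for compound 4 in this assay is 35%, with a range from 10% to 55%.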

Compound 4, a percentage reported as inhibition, in the whole organism at one dose (the size of the read-out at that dose, not a potency): 71%
The estimate for compound 4 lay 36 percentage points below the measured number; the whole stated range lies below it.
By their numbers in this assay, from the lowest: compounds 1, 2 and 4 (each within the scatter of the next). At a limit, below all of these: compound 3.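

In this assay, (1-methyl-1H-imidazol-2-yl)methyl in place of (1-methyl-1H-imidazol-2-yl)sulfanyl on a saturated chain carbon bound to an aromatic carbon gives a number at least 21 percentage points higher from compound 3 to compound 4 (beyond the scatter). For the compounds shown here, this is the first one-place comparison at this position, and it shows that the sulfur atom in the chain is not needed for a measured number in this assay, since the all-carbon 2-(1-methyl-1H-imidazol-2-yl)ethyl chain of compound 4 gives one. Compound 3 stands at a limit, so the size of the step has only a lower bound: the limit of < 50% in this assay, at which 1 of the 4 values shown sits.

As far as these compounds go, whether the same exchange carries over to the ester-bearing core of compound 2 remains open. Also open, from the compounds shown here alone, is how an ether oxygen in the chain, a longer chain, or an amine in place of the 1-methylimidazole would read at this place.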